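The source may hold more compounds than are shown below. What is called first, only, known or untested is meant among the compounds shown, and "the series" means these compounds.

Compound 2 `Cc1ccc2nc(/N=C3\C(=O)N(CN4CCCCC4)c4ccccc43)sc2c1` is the anchor of this small set: in a functional assay on MCF7 cells (Homo sapiens) for cytotoxicity, read by sulforhodamine B assay, with a stated time of 48 h (on this read-out higher numbers stand for weaker inhibition of growth and lower numbers for stronger inhibition of growth), compound 2 gives 37800 nM. Compound 1 `CCN(CC)CN1C(=O)/C(=N\c2nc3ccc(C)cc3s2)c2ccccc21` differs from it by diethylamino in place of piperidin-1-yl on a saturated chain carbon bound to an amide-type nitrogen in a ring, and in this assay compound 1 gives 74800 nM, a step of a 2.0-fold higher number from compound 2 to compound 1 (0.30 log units; within the scatter). Compound 3 `O=C1C(=O)N(CN2CCCCC2)c2cccc(Cl)c21` rests on a different core, and the difference between the two cores is not broken down here; in this assay compound 3 gives 51200 nM. Compound 4 `CCN(CC)CN1C(=O)C(=O)c2c(Cl)cccc21` carries the same change as before, (diethylamino in place of piperidin-1-yl on a saturated chain carbon bound to an amide-type nitrogen in a ring), now on the core of compound 3. Since the earlier step was a 2.0-fold higher number from compound 2 to compound 1 (0.30 log units; within the scatter), a step of about a 1.5-fold higher number from compound 3 to compound 4 (0.17 log units; within the scatter) is expected for compound 4, again within the scatter. Compound 4 is therefore estimated at 75000 nM, with a range from 30000 nM to 200000 nM.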

Compound 4, concentration for 50% growth inhibition: 34100 nM
Compound 4: middle estimate off by 2.2-fold (0.34 log units), on the high side, and the stated range covers the measured number.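

In this assay, the same change on the core of compound 3 gives a 1.5-fold lower number from compound 3 to compound 4 (0.18 log units; within the scatter). Between these two cores, the change does not carry over as one fixed step: the same change on two cores in this assay, a 2.0-fold higher number (0.30 log units; within the scatter) from compound 2 to compound 1 and a 1.5-fold lower number (0.18 log units; within the scatter) from compound 3 to compound 4, 3.0-fold (0.47 log units) apart, beyond the scatter of two such steps. Going by these compounds alone, each step on its own lies within the scatter and each core contributes only one pair, so the result shows that the two steps differ, but it does not show that either amine is better on either core or why the steps differ.

The compounds shown leave open how morpholin-4-yl or dimethylamino would behave in this place on either core. They also leave open what a longer chain to the amine would do.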